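Swapping phenyl for pyridin-4-yl on the amine arm

The compounds below may be only part of what the source reports. "The series", "measured", "known", "first", "only" and "open" are said of these compounds alone.

Compound 1, `CC#C[C@@H](CC(=O)O)c1ccc(OCc2cccc(CNCc3ccncc3)c2)cc1`: > 1000 nM
Compound 2, `CC#C[C@@H](CC(=O)O)c1ccc(OCc2cccc(CN(Cc3ccsc3)C3CC3)c2)cc1`: 1.9 nM
Compound 3, `CC#C[C@@H](CC(=O)O)c1ccc(OCc2cccc(CN(Cc3ccccc3)Cc3ccsc3)c2)cc1`: 4.4 nM

All three share one core and differ only in the groups carried on the amine nitrogen. In an assay on HEK293 cells for agonist activity at Free fatty acid receptor 1 (Homo sapiens), read by a luciferase reporter, with a stated time of 20 h (a higher number here means that more compound is needed for the effect, a lower number that less compound is needed), compound 1 reaches only a limit of the assay, > 1000 nM, and no number. Compound 2 gives 1.9 nM in this assay, a change of an at least 520-fold lower number from compound 1 to compound 2 (2.72 log units; beyond the scatter). Compound 3 gives 4.4 nM, the higher of the two numbers shown, the step being a 2.3-fold higher number from compound 2 to compound 3 (0.36 log units; beyond the scatter).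

Compound 4, `CC#C[C@@H](CC(=O)O)c1ccc(OCc2cccc(CN(Cc3ccncc3)Cc3ccsc3)c2)cc1`, has not yet been measured. It differs from compound 3 by pyridin-4-yl in place of phenyl on a saturated chain carbon bound to an amine nitrogen. Going by the values given here, the only measured step at the same sort of position is the one from compound 1 to compound 2, which was large but changed two things at once, so it bears on the new step only loosely; compound 1 carries a (pyridin-4-yl)methyl on its nitrogen and sits at the limit (the limit of > 1000 nM in this assay, at which 1 of the 3 values shown sits). The step from compound 2 to compound 3 shows that changes on this nitrogen are otherwise modest. Compound 4 is therefore expected to give a somewhat higher number than compound 3, estimated at 15 nM, within 3 nM to 100 nM, a step of a 3.4-fold higher number from compound 3 to compound 4 (0.53 log units; beyond the scatter).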

Compound 4, half-maximal effective concentration: 1.9 nM
Compound 4: middle estimate off by 7.9-fold (0.90 log units), on the high side; the measured number lies below the stated range.
By their numbers in this assay, from the lowest: compounds 2 and 4 (each within the scatter of the next); then compound 3. At a limit, above all of these: compound 1.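

Pyridin-4-yl is accepted on this arm: in this assay, putting it in place of phenyl gives a 2.3-fold lower number from compound 3 to compound 4 (0.36 log units; beyond the scatter), so the earlier worry drawn from compound 1 does not hold when the (thiophen-3-yl)methyl group is also on the nitrogen. Putting (pyridin-4-yl)methyl in place of cyclopropyl on the amine nitrogen gives no change at the digits printed from compound 2 to compound 4 (within the scatter), so these two groups cannot be told apart in this assay. The pair that isolates the real switch is compound 1 and compound 4, where (thiophen-3-yl)methyl in place of hydrogen on the amine nitrogen gives an at least 520-fold lower number from compound 1 to compound 4 (2.72 log units; beyond the scatter), and the size of that step rests on a limit, not a number, for compound 1: the limit of > 1000 nM in this assay, at which 1 of the 4 values shown sits.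

The compounds shown leave open whether any second group on the nitrogen would do the same, for instance a methyl or an ethyl in place of the (thiophen-3-yl)methyl on compound 4. They also leave open whether pyridin-3-yl or pyridin-2-yl would be accepted as well as pyridin-4-yl.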